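The source may hold more compounds than are shown below. What is called first, only, known or untested is meant among the compounds shown, and "the series" means these compounds.

Measured set in a functional assay on the whole organism (Tail, strain ICR) with Mus musculus as the target, in the tail flick test, with a stated time of 90 min, at a dose of 25 umol/kg by the oral route; a higher number here means a stronger effect of the compound at the dose given, a lower number a weaker effect: compound 1 `CSCC[C@H](NC(=O)CN(c1nc(Cl)nc2[nH]cnc12)C1CC1)C(=O)OCc1ccccc1` gives 44.6%; compound 2 `CC(C)[C@H](NC(=O)CN(c1ncnc2c1ncn2C1CCCCO1)C1CC1)C(=O)OCc1ccccc1` gives 30.1%; compound 3 `NC(=O)CC[C@H](NC(=O)CN(c1nc(Cl)nc2[nH]cnc12)C1CC1)C(=O)OCc1ccccc1` gives 42.8%.

Compound 2 stands lowest of the three numbers; compound 3 and compound 1 both sit above it by gaps beyond the scatter.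

Compound 4 `C[C@@H](O)[C@H](NC(=O)CN(c1ncnc2c1ncn2C1CCCCO1)C1CC1)C(=O)OCc1ccccc1` differs from compound 2 by 1-hydroxyethyl in place of isopropyl on a saturated chain carbon bound to an amide-type nitrogen and a carbonyl carbon. Among the measured compounds shown here, one measured step bears on a change of the side group on the chain carbon near the amide-type nitrogen and carbonyl carbon: a number 1.8 percentage points lower from compound 1 to compound 3 (within the scatter), a swap of one three-heavy-atom group for another that left the read-out unchanged. The same is therefore expected here: no step beyond the scatter in this assay, a number 0.9 percentage points higher from compound 2 to compound 4 (within the scatter). Compound 4 is estimated at 31%, with a range from 19% to 43%.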

Compound 4, a percentage reported as activity, at one dose (the size of the read-out at that dose, not a potency): 23.4%
Estimate against measurement, compound 4: 7.6 percentage points above, and the stated range covers the measured number.
By their numbers in this assay, from the lowest: compounds 4 and 2 (each within the scatter of the next); then compounds 3 and 1 (each within the scatter of the next).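

In this assay, 1-hydroxyethyl in place of isopropyl on this chain carbon gives a number 6.7 percentage points lower from compound 2 to compound 4 (within the scatter). The entering group brings a hydrogen-bond donor and a hydrogen-bond acceptor at the same heavy-atom count, yet the read-out stays within the scatter, so this side-group swap on the core of compound 2 matches the earlier swap on the core of compound 1. Nothing available explains this outcome. Still open, from the compounds shown here alone, is whether an amine, a carboxylic acid or a longer chain on this carbon would move the read-out beyond the scatter. A read-out at one dose also leaves potency open.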